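An Ester Group Replaces a Nitrile on the Shared Core

The source may report more compounds than this note shows. Statements on the series, on what has been measured and on what is new or still open speak of the compounds shown alone.

Of the compounds shown here, three built on one shared core have been tested in a functional assay on the whole organism (stomach) for inhibition, with Canis familiaris (Canis lupus familiaris) as the target, at a dose of 5 mg/kg by the intravenous route; a lower number here means a weaker effect, a higher number a stronger effect of the compound at the dose given. Compound 1 `Cc1nc2c(OCc3ccccc3)cccn2c1C(N)=O` bears a carbamoyl group on an aromatic carbon and gives 2%. Compound 2 `Cc1nc2c(OCc3ccccc3)cccn2c1C#N` bears a cyano group on that aromatic carbon and gives 4%. Compound 3 `Cc1nc2c(OCc3ccccc3)cccn2c1Cl` bears chloro on that aromatic carbon and gives 37%. On these numbers compound 2 stands second highest of the three; its value and that of compound 1 lie within the scatter of each other, while compound 3 lies beyond it. The step of a number 2 percentage points higher from compound 1 to compound 2 (within the scatter) is small, whereas a number 35 percentage points higher from compound 1 to compound 3 (beyond the scatter) and a number 33 percentage points higher from compound 2 to compound 3 (beyond the scatter) are both large.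

Compound 4 `CCCCC(=O)OCc1c(C)nc2c(OCc3ccccc3)cccn12` has not yet been measured. It differs from compound 2 in a single place: ((butylcarbonyl)oxy)methyl in place of cyano on an aromatic carbon. For the measured compounds named here, no measured step involves the entering group, so the only guidance is that exchanging cyano for another small group gave either no change or a large rise. Going by the values given here, the measured steps show that what sits on this aromatic carbon can matter a great deal, but a group of this size has no precedent among the three, so the direction is uncertain. For compound 4 in this assay a value of 20% is expected, between 3% and 50%. This estimate corresponds to an expected step of a number 16 percentage points higher from compound 2 to compound 4 (beyond the scatter).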

Compound 4, a percentage reported as inhibition, in the whole organism at one dose (the size of the read-out at that dose, not a potency): 96%
Compound 4: the middle estimate sits 76 percentage points below what was measured, and the stated range ends below it.
By their numbers in this assay, from the lowest: compounds 1 and 2 (each within the scatter of the next); then compound 3; then compound 4.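

In this assay the ((butylcarbonyl)oxy)methyl group stands clearly above the other three groups on this aromatic carbon, with a number 92 percentage points higher from compound 2 to compound 4 (beyond the scatter) and a number 94 percentage points higher from compound 1 to compound 4 (beyond the scatter) and even a number 59 percentage points higher from compound 3 to compound 4 (beyond the scatter). Chloro therefore does not mark the upper end at this position, and a group of 8 heavy atoms with an ester carbonyl, replacing a cyano group of 2 heavy atoms, goes with the highest number of the series rather than a loss of effect. None of the available data offers a reason for this large rise.

The compounds shown leave open which part of the entering group goes with the high number: the ester, the butyl chain or simply the larger size, a question that a hydroxymethyl group, an acetyloxymethyl group or a plain pentyl chain on the same carbon could help to settle. They also leave open how these compounds compare at other doses, as a read-out at a single dose shows the size of the effect at that dose and not a potency.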